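Chloro for Methoxy, Repeated on a Longer Chain

This account rests on a few compounds, and the source may have more. Where it says the series, first, only, none or still open, it means among the compounds named here.

Compound 1, `COc1ccccc1N1CCN(CCCCCn2ncc(N3CCN(C(=O)c4ccco4)CC3)c(Cl)c2=O)CC1`: 1.9 nM
Compound 2, `O=C(c1ccco1)N1CCN(c2cnn(CCCCCN3CCN(c4ccccc4Cl)CC3)c(=O)c2Cl)CC1`: 3.6 nM
Compound 3, `COc1ccccc1N1CCN(CCCCCCCn2ncc(N3CCN(C(=O)c4ccco4)CC3)c(Cl)c2=O)CC1`: 1.9 nM

Of the compounds shown here, three have been measured in an assay on cell membranes for binding affinity to Adrenergic receptor alpha-1 (Rattus norvegicus), read by radioligand binding; a higher number here means a weaker inhibitor, a lower number a stronger inhibitor. Compound 1 gives 1.9 nM and compound 3 gives 1.9 nM; the two numbers agree at the digits given, and the difference between their cores is not broken down here. Compound 2 gives 3.6 nM. It differs from compound 1 in one place only, (chloro in place of methoxy on an aromatic carbon), and this change gave a 1.9-fold higher number from compound 1 to compound 2 (0.28 log units; within the scatter), a step that stays within the scatter of repeated measurements.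

Compound 4, `O=C(c1ccco1)N1CCN(c2cnn(CCCCCCCN3CCN(c4ccccc4Cl)CC3)c(=O)c2Cl)CC1`, is not yet measured in this assay. It stands to compound 3 exactly as compound 2 stands to compound 1: chloro in place of methoxy on an aromatic carbon. The place of the change is the same in both pairs, so this is the same change, made on the core of compound 3. Since the earlier step was a 1.9-fold higher number from compound 1 to compound 2 (0.28 log units; within the scatter), the expected step from compound 3 to compound 4 is a 1.9-fold higher number from compound 3 to compound 4 (0.28 log units; within the scatter), resting on that single precedent. Compound 4 is therefore estimated at 3.6 nM, expected to fall between 1.5 nM and 9 nM.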

Compound 4, inhibition constant: 11.5 nM
Compound 4: middle estimate off by 3.2-fold (0.50 log units), on the low side; measured number outside the range, above it.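

On the core of compound 3, chloro in place of methoxy on the aromatic ring gave a 6.1-fold higher number from compound 3 to compound 4 (0.78 log units; beyond the scatter) in this assay. The size of this step therefore did not carry over intact from one core to the other: the same change on two cores in this assay, a 1.9-fold higher number (0.28 log units; within the scatter) from compound 1 to compound 2 and a 6.1-fold higher number (0.78 log units; beyond the scatter) from compound 3 to compound 4, 3.2-fold (0.50 log units) apart, beyond the scatter of two such steps The number rose on both cores, but the earlier step lies within the scatter, so even this shared direction is weak support, and two pairs cannot show how the step depends on the core or why the two sizes differ.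

Methoxy and chloro are the only groups compared at this place on the ring, so it remains open whether a fluoro or a methyl group there would also depend on the core. The chain is also tested only in the forms shown, so it is unknown how the step would behave on a shorter or a longer chain.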